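The source may hold more compounds than are shown below. What is called first, only, known or untested is meant among the compounds shown, and "the series" means these compounds.

Compound 1 `Fc1cccc(/C=N/NC(=S)Nc2cccc3ccccc23)c1F`: 500 ug/mL
Compound 2 `Fc1ccc(/C=N/NC(=S)Nc2cccc3ccccc23)cc1Cl`: 51.3 ug/mL

Within the data shown here, in a functional assay on A549 cells (Homo sapiens) for cytotoxicity, read by XTT assay, with a stated time of 24 h (on this read-out lower numbers stand for stronger inhibition and higher numbers for weaker inhibition), compound 2 stands at the lowest of the two numbers, with compound 1 its only neighbour; the step is a 9.7-fold lower number from compound 1 to compound 2 (0.99 log units; beyond the scatter). Compound 3 `Fc1cc(F)cc(/C=N/NC(=S)Nc2cccc3ccccc23)c1` differs from compound 2 by 3,5-difluorophenyl in place of 3-chloro-4-fluorophenyl on a carbon with a double bond to nitrogen. Among the measured compounds shown here, the one measured step concerns a different exchange on the same carbon, so it bears on the new change only loosely, showing that swapping the ring at this position can move the number modestly. Compound 3 is expected to give 150 ug/mL, within 50 ug/mL to 500 ug/mL, meaning an estimated 2.9-fold higher number from compound 2 to compound 3 (0.47 log units; beyond the scatter).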

Compound 3, half-maximal inhibitory concentration: 500 ug/mL
For compound 3 the middle estimate is 3.3-fold (0.52 log units) below the measured one; measured number inside the range.
By their numbers in this assay, from the lowest: compound 2; then compounds 1 and 3 (each within the scatter of the next).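

In this assay the change to 3,5-difluorophenyl gives a 9.7-fold higher number from compound 2 to compound 3 (0.99 log units; beyond the scatter), so the low number of compound 2 does not carry over to this ring. Exchanging 2,3-difluorophenyl for 3,5-difluorophenyl gives no change at the digits printed from compound 1 to compound 3 (within the scatter), leaving the two difluorophenyl compounds together and only the 3-chloro-4-fluorophenyl compound apart among these three. No supporting information accounts for this difference. The compounds shown leave open whether the chlorine itself matters or only the whole substitution pattern. They also leave open how an amine or a carboxylic acid on this ring would read.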